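Amide substituent variation on a shared core in rat paw edema

The compounds below may be only part of what the source reports. "The series", "measured", "known", "first", "only" and "open" are said of these compounds alone.

Compound 1 `CN(C)CCNC(=O)c1c(O)c2cccnc2n(-c2ccccc2)c1=O` and compound 2 `O=C(Nc1cccc(Cl)c1)c1c(O)c2cccnc2n(-c2ccccc2)c1=O` share a core and differ only at the amide-type nitrogen. In a functional assay on the whole organism for inhibition, with Rattus norvegicus as the target, read by cytopathic effect and paw edema, at a dose of 100 mg/kg by the oral route (a higher number here means more inhibition at the dose given (going by the name of the read-out), a lower number less inhibition), compound 1 gives 18.4%, and compound 2 gives 13.4%. The one measured step, a number 5 percentage points lower from compound 1 to compound 2 (within the scatter), leaves the two numbers within the scatter of each other, so compound 2 stands at a level not distinguishable from compound 1 on the numbers shown.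

Compound 3 `O=C(Nc1cccnc1)c1c(O)c2cccnc2n(-c2ccccc2)c1=O` carries the change (pyridin-3-yl in place of 3-chlorophenyl on an amide-type nitrogen). For the measured compounds named here, no measured step involves this exchange of a carbon-only ring for a ring with one hetero atom; the only step available, from a chain to an aryl group, was within the scatter. With nothing in the data pointing to a shift, no step beyond the scatter is expected, and compound 3 is estimated to give 14% (range 4% to 26%), meaning an expected step of a number 0.6 percentage points higher from compound 2 to compound 3 (within the scatter) in this assay.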

Compound 3, a percentage reported as inhibition, in the whole organism at one dose (the size of the read-out at that dose, not a potency): 30.8%
Beside the measured number, compound 3's estimate is 16.8 percentage points below it; measured number above the stated range.
By their numbers in this assay, from the lowest: compounds 2 and 1 (each within the scatter of the next); then compound 3.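

For the compounds shown here, the amide-type nitrogen now shows a difference in this assay: pyridin-3-yl in place of 3-chlorophenyl gives a number 17.4 percentage points higher from compound 2 to compound 3 (beyond the scatter), the first step beyond the scatter. Pyridin-3-yl in place of 2-(dimethylamino)ethyl gives a number 12.4 percentage points higher from compound 1 to compound 3 (beyond the scatter), so this ring with one hetero atom stands clear of both other groups, which remain within the scatter of each other. No measurement at hand offers an explanation for this difference.

The step from 3-chlorophenyl to pyridin-3-yl changes a ring carbon to nitrogen and removes the chlorine together, so the compounds shown do not separate these two changes, and unsubstituted phenyl on the same nitrogen would bear on that. Also open, as far as these compounds go, is how a pyrimidinyl ring or a longer chain ending in a carboxylic acid would read at this nitrogen.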